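A few compounds are considered here, and "the series" means these few. Any claim that something is new, unique, unknown or untested is made for them only; others in the source may bear on it.

In an ADME assay on HaCaT cells (Homo sapiens) for inhibition, read by sulforhodamine B assay, with a stated time of 48 h (on this read-out lower numbers stand for stronger inhibition of growth and higher numbers for weaker inhibition of growth), compound 3 `CCc1ccc(NC(=S)N/N=C/c2cccs2)cc1` gives 17600 nM. Compound 1 `Cc1ccc(NC(=S)N/N=C/c2cccs2)cc1` gives 17600 nM, and the step between them is no change at the digits printed from compound 1 to compound 3 (within the scatter). Compound 2 `COc1ccc(NC(=S)N/N=C/c2cccs2)cc1` reads > 100000 nM, which is a limit of the assay and not a number. Methoxy is the one change that moves the read-out, with an at least 5.6-fold higher number from compound 1 to compound 2 (0.75 log units; beyond the scatter) and an at least 5.6-fold lower number from compound 2 to compound 3 (0.75 log units; beyond the scatter). Compound 4 `S=C(N/N=C/c1cccs1)Nc1ccc(Br)cc1` carries bromo in place of ethyl on an aromatic carbon, para to a large group: bromo in place of ethyl on an aromatic carbon. Within the data shown here, no measured compound has bromo, so the closest guide is the flat alkyl pair, compound 1 and compound 3, with no change at the digits printed from compound 1 to compound 3 (within the scatter), while compound 2 warns of a possible rise. The expected step is a 1.1-fold higher number from compound 3 to compound 4 (0.06 log units; within the scatter), an estimate that stays within the scatter. Compound 4 is expected at an estimated 20000 nM, with a range of 7000 nM to 60000 nM.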

Compound 4, concentration for 50% growth inhibition: 800 nM
Compound 4: the middle estimate sits 25-fold (1.40 log units) above what was measured, and the stated range ends above it.
By their numbers in this assay, from the lowest: compound 4; then compounds 1 and 3 (each within the scatter of the next). At a limit, above all of these: compound 2.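

At this position, on an aromatic carbon para to a large group, the read-out does respond to the group, and methyl and ethyl level with each other do not predict bromo: a 22-fold lower number from compound 3 to compound 4 (1.34 log units; beyond the scatter), and a 22-fold lower number from compound 1 to compound 4 (1.34 log units; beyond the scatter). Against methoxy, the change gives an at least 120-fold lower number from compound 2 to compound 4 (2.09 log units; beyond the scatter). Compound 2 reads as a limit and not a number: the limit of > 100000 nM in this assay, at which 1 of the 4 values shown sits.

As far as these compounds go, whether the lower number belongs to bromo alone stays open, as chloro, iodo or an amine in this place would be needed to tell. Also open, from the compounds shown here alone, is whether bromo elsewhere on this ring reads the same.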